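The compounds below may be only part of what the source reports. "The series", "measured", "known", "first", "only" and "open" are said of these compounds alone.

Measured so far in a functional assay on LOX IMVI cells (Homo sapiens) for cytotoxicity, read by MTT assay, with a stated time of 24 h; on this read-out lower numbers stand for stronger inhibition and higher numbers for weaker inhibition:
- compound 1 `O=S(=O)(NCCCNc1nccc(-c2[nH]c(-c3ccccc3)nc2-c2ccc(Cl)c(O)c2)n1)c1ccc(Cl)cc1`: 61300 nM
- compound 2 `COc1ccc(S(=O)(=O)NCCCNc2nccc(-c3[nH]c(-c4ccccc4)nc3-c3ccc(Cl)c(O)c3)n2)cc1`: 36800 nM

Only these two compounds have been measured, and compound 2 lies within the usual scatter of compound 1, so the two numbers cannot be told apart. Both sit on the same shared core and differ only in the aromatic group on the sulfonyl sulfur.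

The next compound is compound 3 `O=S(=O)(NCCCNc1nccc(-c2[nH]c(-c3ccccc3)nc2-c2ccc(Cl)c(O)c2)n1)c1cccc2ccccc12`, in which naphthalen-1-yl stands in place of 4-methoxyphenyl on a sulfonyl sulfur: naphthalen-1-yl in place of 4-methoxyphenyl on a sulfonyl sulfur.

Within the data shown here, one measured step bears on this change. Methoxy in place of chloro on an aromatic carbon gave a 1.7-fold lower number from compound 1 to compound 2 (0.22 log units; within the scatter). That step is small, but it is only a partial guide, since neither measured compound carries a second aromatic ring in this group. Resting on that step, no shift beyond the scatter is expected in this assay, and the direction remains open.

The expected step is a 1.1-fold lower number from compound 2 to compound 3 (0.05 log units; within the scatter). For compound 3 the estimated value is 33000 nM, with an expected range from 13000 nM to 80000 nM.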

Compound 3, half-maximal inhibitory concentration: 7720 nM
Beside the measured number, compound 3's estimate is 4.3-fold (0.63 log units) above it, and the stated range ends above it.
By their numbers in this assay, from the lowest: compound 3; then compounds 2 and 1 (each within the scatter of the next).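

In this assay the group on the sulfonyl sulfur proves able to move the number beyond the scatter, since naphthalen-1-yl in place of 4-methoxyphenyl gave a 4.8-fold lower number from compound 2 to compound 3 (0.68 log units; beyond the scatter) and naphthalen-1-yl in place of 4-chlorophenyl gave a 7.9-fold lower number from compound 1 to compound 3 (0.90 log units; beyond the scatter). The earlier exchange of chloro for methoxy on a single aromatic ring had stayed within the scatter, so compounds 1 and 2 gave no sign that this position could matter; with two six-membered aromatic rings of carbon only on the sulfur, compound 3 now stands apart from both as the lowest of the three. Nothing available accounts for this shift.

The compounds shown leave open whether the lower number follows the second aromatic ring itself or its particular attachment, a question that naphthalen-2-yl, quinolin-8-yl or a saturated cyclohexyl on the same sulfur would address. They also leave open whether the step from compound 2 to compound 3 would hold with a longer chain in place of the one linking the sulfonamide nitrogen to the shared core.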